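A few compounds are considered here, and "the series" means these few. Any claim that something is new, unique, unknown or untested is made for them only; others in the source may bear on it.

Of the compounds shown here, three have so far been tested in a functional assay on NB-4 cells (Homo sapiens) for inhibition, read by XTT assay, with a stated time of 48 h (on this read-out higher numbers stand for weaker inhibition and lower numbers for stronger inhibition), and a fourth awaits measurement. Compound 1, `COc1ccc(C(=O)/C(=C/C2CCCCC2)COC(C)=O)cc1`, and compound 2, `COc1ccc(C(=O)/C(=C/C2CCCCC2)COC(=O)c2ccccc2)cc1`, are built on one shared core and differ at a single point. Compound 3, `C=C(C(=O)c1ccc(OC)cc1)C(OC(C)=O)c1ccccc1F`, stands on a different core; the difference between the two cores is not broken down here. Compound 4, `C=C(C(=O)c1ccc(OC)cc1)C(OC(=O)c1ccccc1)c1ccccc1F`, is the one still to be measured.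

In this assay compound 1 gives 23300 nM, while compound 2 gives 10200 nM. The change that separates them is phenyl in place of methyl on a carbonyl carbon, and it produced a step of a 2.3-fold lower number from compound 1 to compound 2 (0.36 log units; beyond the scatter). Compound 3 gives 9500 nM, a number that sits close to that of compound 2 and clearly below that of compound 1.

Compound 4 arises from compound 3 by the same change, phenyl in place of methyl on a carbonyl carbon: the group that leaves, the group that enters and the surroundings of the place are the same as before, so this is the same change carried onto the other core. Among all four compounds this change occurs twice. Within the data shown here, the expectation is that it lowers the number again by roughly the same amount, because on the first core it gave a 2.3-fold lower number from compound 1 to compound 2 (0.36 log units; beyond the scatter); with only one earlier example the size is uncertain. Compound 4 is therefore estimated at 4500 nM, within a range from 2000 nM to 11000 nM. This estimate corresponds to an expected step of a 2.1-fold lower number from compound 3 to compound 4 (0.32 log units; beyond the scatter).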

Compound 4, half-maximal inhibitory concentration: 14300 nM
Beside the measured number, compound 4's estimate is 3.2-fold (0.50 log units) below it; measured number outside the range, above it.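

In this assay, putting phenyl in place of methyl on the carbonyl carbon of the acetoxy group gave a 1.5-fold higher number from compound 3 to compound 4 (0.18 log units; within the scatter), so on this core the acetoxy and benzoyloxy compounds cannot be told apart. The gain seen on the first core therefore did not carry over to the second, and the gap between the two steps is larger than chance scatter would readily explain: the same change on two cores in this assay, a 2.3-fold lower number (0.36 log units; beyond the scatter) from compound 1 to compound 2 and a 1.5-fold higher number (0.18 log units; within the scatter) from compound 3 to compound 4, 3.4-fold (0.54 log units) apart, beyond the scatter of two such steps. This shows that, in this small series, the effect of the change depends on the core that carries it, but it does not show which part of the cores is responsible, and with a single pair on each core it does not establish how large the effect would be on a third core.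

Going by these compounds, only methyl and phenyl have been compared at this place, so it remains open how either core would respond to a longer chain such as butyl, or to a phenyl ring carrying an amine or a carboxylic acid. On these data alone, it also remains open whether swapping parts of the two cores one at a time would reveal which difference between them separates the two outcomes.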